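Compound 3: what the cytotoxicity limits allow

The source may report more compounds than this note shows. Statements on the series, on what has been measured and on what is new or still open speak of the compounds shown alone.

In an ADME assay on L929 cells (Mus musculus) for cytotoxicity, read by resazurin assay, with a stated time of 72 h (on this read-out higher numbers stand for weaker inhibition and lower numbers for stronger inhibition), compound 1 `O=C(/C=C/c1ccc2c(c1)B(O)OC2)c1ccco1` gives > 10 ug/mL and this is a limit of the assay, not a number. Compound 2 `Cn1cccc1C(=O)/C=C/c1ccc2c(c1)B(O)OC2` gives > 10 ug/mL and this too is a limit. For the measured compounds named here, compound 2 therefore stands only at a limit, and the one other value shown is also a limit. Going by the values given here, the only measured step is a step that the two limits leave unreadable from compound 1 to compound 2 and so offers no size to carry forward.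

The next compound is compound 3 `O=C(/C=C/c1ccc2c(c1)B(O)OC2)c1cccc(O)c1` with 3-hydroxyphenyl in place of 1-methyl-1H-pyrrol-2-yl on a carbonyl carbon. Among the compounds with values here, no measured step involves this group. The only support is the limit of > 10 ug/mL in this assay, at which 2 of the 2 values shown sit, and it sets no size for the change.

Compound 3 is expected to read as a limit as well, and no step beyond the scatter is expected in this assay in either direction because of the limit of > 10 ug/mL in this assay, at which 2 of the 2 values shown sit, and the unreadable step above. The estimated change is a step that the limit leaves unreadable from compound 2 to compound 3 and no direction can be attached to it. For compound 3 the estimated value is 15 ug/mL (expected range 5 ug/mL to 45 ug/mL).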

Compound 3, half-maximal inhibitory concentration: 7.56 ug/mL
Beside the measured number, compound 3's estimate is 2.0-fold (0.30 log units) above it, and the stated range covers the measured number.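

In this assay, for the compounds shown here, compound 3 is the first of the series to give a number and not a limit, so a group on the carbonyl carbon can bring the reading into the measurable range. With 3-hydroxyphenyl in place of 1-methyl-1H-pyrrol-2-yl the result is an at least 1.3-fold lower number from compound 2 to compound 3 (0.12 log units; that floor lies within the scatter), and with 3-hydroxyphenyl in place of furan-2-yl it is an at least 1.3-fold lower number from compound 1 to compound 3 (0.12 log units; that floor lies within the scatter). Both floors lie within the scatter, and the true size of either change stays unfixed because each of the two partners of compound 3 stands only at a limit: the limit of > 10 ug/mL in this assay, at which 2 of the 3 values shown sit.

The compounds shown do not separate the hydroxyl group from the six-membered aromatic ring of carbon only as the source of the reading in this assay, and a plain phenyl group or a methoxyphenyl group on the carbonyl carbon would bear on that. On these data alone, how an amine or a carboxylic acid in that place would read, and whether any such group moves the number beyond the scatter, also remains open.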